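Sulfonyl group swap from compound 1 to compound 4

The source may report more compounds than this note shows. Statements on the series, on what has been measured and on what is new or still open speak of the compounds shown alone.

In a functional assay on HeLa cells (Homo sapiens) for inhibition, read by sulforhodamine B assay, with a stated time of 74 h (on this read-out lower numbers stand for stronger inhibition and higher numbers for weaker inhibition), compound 1 `Cc1ccc(S(=O)(=O)N2C(=O)COC23C=CC(=O)C=C3)cc1` gives 180 nM, the lower of the two numerical values. Compound 3 `O=C1C=CC2(C=C1)OCC(=O)N2S(=O)(=O)c1ccc(C(F)(F)F)cc1` gives 770 nM. Compound 2 `Cc1ccc(S(=O)(=O)N2C(=O)C(C)OC23C=CC(=O)C=C3)cc1` reads > 10000 nM, which is a limit of the assay.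

Compound 4 `O=C1C=CC2(C=C1)OCC(=O)N2S(=O)(=O)c1cccs1` is the next case: thiophen-2-yl in place of 4-methylphenyl on a sulfonyl sulfur. In words, thiophen-2-yl in place of 4-methylphenyl on a sulfonyl sulfur.

The step on the aromatic group carried by the sulfonyl sulfur bears most directly and is modest: a 4.3-fold higher number from compound 1 to compound 3 (0.63 log units; beyond the scatter). The large step of an at least 55-fold higher number from compound 1 to compound 2 (1.74 log units; beyond the scatter) lies on a saturated ring carbon and bears less. A modest step towards a higher number is therefore expected: a 1.7-fold higher number from compound 1 to compound 4 (0.22 log units; within the scatter). The estimated value for compound 4 is 300 nM, with an expected range of 100 nM to 1000 nM.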

Compound 4, half-maximal inhibitory concentration: 3420 nM
Estimate against measurement, compound 4: 11-fold (1.06 log units) below; the whole stated range lies below it.
By their numbers in this assay, from the lowest: compound 1; then compound 3; then compound 4. At a limit, above all of these: compound 2.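

In this assay, replacing the whole 4-methylphenyl ring on the sulfonyl sulfur gives a 19-fold higher number from compound 1 to compound 4 (1.28 log units; beyond the scatter), a large step where the trifluoromethyl change gave only a 4.3-fold higher number from compound 1 to compound 3 (0.63 log units; beyond the scatter). Both changes at this position raise the number, so the ring itself matters here and not only its methyl group. Nothing measured on these compounds accounts for the thiophen-2-yl step.

Still open, from the compounds shown here alone, is how a 4-aminophenyl or 4-carboxyphenyl group on the sulfonyl sulfur, or a simple alkyl chain in place of the ring, would compare with compound 1.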